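Fluoro to methyl on the aryl group of compound 1

The compounds below may be only part of what the source reports. "The series", "measured", "known", "first", "only" and "open" are said of these compounds alone.

Compound 1 `Cc1nnc(SCC(=O)N/N=c2/scc(-c3ccc(F)cc3)n2-c2ccccc2)s1` carries a fluoro on the aromatic carbon of the six-membered ring of carbon only. In a functional assay on C6 cells (Rattus norvegicus) for cytotoxicity, read by MTT assay, with a stated time of 24 h, tested at 12 ug/mL (a higher number here means a weaker effect of the compound at the concentration tested, a lower number a stronger effect), compound 1 gives 73.7%, the highest of the three numbers recorded, so its effect at the test concentration is the weakest of the set. For the measured compounds named here, compound 2 `O=C(CSc1nnnn1-c1ccccc1)N/N=c1/scc(-c2ccc(F)cc2)n1-c1ccccc1` gives 60% in this assay, and the step of a number 13.7 percentage points lower from compound 1 to compound 2 (beyond the scatter) is the only single-point change with a measurement. Compound 3 `Cn1nnnc1SCC(=O)N/N=c1/scc(-c2ccc(C#N)cc2)n1-c1ccccc1` gives 53.9%, but it differs from compound 1 in two places, so its gap from compound 1 cannot be tied to one change.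

Compound 4 `Cc1ccc(-c2cs/c(=N/NC(=O)CSc3nnc(C)s3)n2-c2ccccc2)cc1` differs from compound 1 by methyl in place of fluoro on an aromatic carbon. Going by the values given here, no measured step touches this position: the one measured step sits on the sulfur, and the nitrile of compound 3 is not isolated. In this assay, therefore, nothing shown points to a step beyond the scatter in either direction, and the expectation is a change close to none.

Compound 4 is expected to give 70%, within 55% to 85%, in this assay. The step of a number 3.7 percentage points lower from compound 1 to compound 4 (within the scatter) is the estimated result of that exchange.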

Compound 4, a percentage reported as activity, at one concentration (the size of the read-out at that concentration, not a potency): 58.3%
Beside the measured number, compound 4's estimate is 11.7 percentage points above it; measured number inside the range.
By their numbers in this assay, from the lowest: compounds 3, 4 and 2 (each within the scatter of the next); then compound 1.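

For the compounds shown here, the exchange of fluoro for methyl on an aromatic carbon, para to a large group, gives the first measured step at this position: in this assay the change from 4-fluorophenyl to 4-methylphenyl brings a number 15.4 percentage points lower from compound 1 to compound 4 (beyond the scatter) and so a stronger effect at the concentration tested, which shows that the read-out responds to this position and not only to the group on the sulfur. Read from compound 1, this step and a number 13.7 percentage points lower from compound 1 to compound 2 (beyond the scatter) both go in the same direction and each lies beyond the scatter, so compound 1 is improved on by a single change at either of two separate places. The measurements shown offer nothing that would explain why a methyl and a fluoro differ here.

Still open, as far as these compounds go, is whether the same exchange gives a step of this kind on the 1-phenyl-1H-tetrazol-5-yl compound 2, and whether the changes at the two places add up. Also open, from the compounds shown here alone, is how an amine, a carboxylic acid or a longer chain such as propyl on the same aromatic carbon would read in this assay and whether the direction seen with methyl would persist.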